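Linker rigidity on a hydroxamate-bearing imidazoline series

This account rests on a few compounds, and the source may have more. Where it says the series, first, only, none or still open, it means among the compounds named here.

Compound 2 `CCOc1cc(C(C)(C)C)ccc1C1=NC(c2ccc(Cl)cc2)C(c2ccc(Cl)cc2)N1C(=O)NCCCCCCCC(=O)NO` gives 5030 nM in a functional assay on HCT-116 cells (Homo sapiens) for antiproliferative activity, read by CCK-8 assay, with a stated time of 72 h; a higher number here means a weaker inhibitor, a lower number a stronger inhibitor. Going by the values given here, of the three numbers so far it is the lowest, yet its steps to compound 1 `CCOc1cc(C(C)(C)C)ccc1C1=NC(c2ccc(Cl)cc2)C(c2ccc(Cl)cc2)N1C(=O)NCCCCCCCC(=O)Nc1ccccc1N`, at 9910 nM, and to compound 3 `CCOc1cc(C(C)(C)C)ccc1C1=NC(c2ccc(Cl)cc2)C(c2ccc(Cl)cc2)N1C(=O)NCCCCCCC(=O)Nc1ccccc1N`, at 10100 nM, are both within the scatter, so no ranking among the three is supported. The measured steps of a 2.0-fold lower number from compound 1 to compound 2 (0.29 log units; within the scatter), a 1.0-fold higher number from compound 1 to compound 3 (0.01 log units; within the scatter) and a 2.0-fold higher number from compound 2 to compound 3 (0.30 log units; within the scatter) concern the terminal group and the chain length only; none of them reaches beyond the scatter.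

Compound 4 `CCOc1cc(C(C)(C)C)ccc1C1=NC(c2ccc(Cl)cc2)C(c2ccc(Cl)cc2)N1C(=O)NCc1ccc(C(=O)NO)cc1` differs from compound 2 in the linker: 4-(hydroxycarbamoyl)phenyl in place of 6-(hydroxycarbamoyl)hexyl on a saturated chain carbon bound to an amide-type nitrogen. Among the compounds with values here, no measured pair speaks to an exchange of a flexible chain for an aromatic ring, so the only guidance is that every step seen has been flat. The step from compound 2 to compound 4 is therefore expected to be a 1.0-fold lower number from compound 2 to compound 4 (0.00 log units; within the scatter), with the uncertainty widened for the untested change. For compound 4 a value of 5000 nM is expected, between 1500 nM and 16000 nM.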

Compound 4, half-maximal inhibitory concentration: 9100 nM
For compound 4 the middle estimate is 1.8-fold (0.26 log units) below the measured one; low and high end bracket the measured number.
By their numbers in this assay, from the lowest: compounds 2, 4, 1 and 3 (each within the scatter of the next).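

In this assay, placing 4-(hydroxycarbamoyl)phenyl in place of 6-(hydroxycarbamoyl)hexyl on a saturated chain carbon bound to an amide-type nitrogen gives a 1.8-fold higher number from compound 2 to compound 4 (0.26 log units; within the scatter) and so stays flat. The earlier steps shown here covered only the terminal group and chain length, whereas this one shows that a six-membered aromatic ring of carbon only can replace a chain with no ring, at the same heavy-atom count, without a step beyond the scatter. Nothing available gives a reason for this flat result.

The compounds shown leave open whether a carboxylic acid in place of the hydroxycarbamoyl end, or a chain longer than 7-(hydroxycarbamoyl)heptyl, would give a step beyond the scatter. They also leave open whether a pyridine ring in place of the benzene ring of 4-(hydroxycarbamoyl)benzyl would do so.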